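Cyano in place of methylsulfonyl: expectation for compound 3

This account rests on a few compounds, and the source may have more. Where it says the series, first, only, none or still open, it means among the compounds named here.

Two mirror-image compounds share the core: compound 1 `CC(C)(C)OC(=O)N1CCC(O[C@H]2CC[C@@H](Oc3ccc(S(C)(=O)=O)cc3)CC2)CC1` and compound 2 `CC(C)(C)OC(=O)N1CCC(O[C@H]2CC[C@H](Oc3ccc(S(C)(=O)=O)cc3)CC2)CC1`. In a functional assay on isolated protein for agonist activity at Glucose-dependent insulinotropic receptor (Rattus norvegicus), read by HTRF and cAMP accumulation (on this read-out lower numbers stand for smaller maximal responses and higher numbers for larger maximal responses), compound 1 gives 121%. In this assay, within the data shown here, compound 2 gives 120%, so compound 2 sits within the scatter of compound 1, the only other number known. Among the measured compounds shown here, the step of a number 1 percentage points lower from compound 1 to compound 2 (within the scatter) is the sole measured step, and it is tied to the fact that compounds 1 and 2 differ only in the configuration as drawn; it carries no information on an exchange of the aromatic substituent.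

Compound 3 `CC(C)(C)OC(=O)N1CCC(O[C@H]2CC[C@H](Oc3ccc(C#N)cc3)CC2)CC1` is the next compound to be measured in this assay. Relative to compound 2 the change is cyano in place of methylsulfonyl on an aromatic carbon. For the measured compounds named here, no measured step touches this substituent, so the expectation rests on compound 2 alone, and no direction of change can be read from the present numbers. The expected step of a number 5 percentage points lower from compound 2 to compound 3 (within the scatter) is therefore set at none beyond the scatter, with a broader range to allow for the untested exchange. For compound 3 the estimate in this assay is 115%, between 90% and 135%.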

Compound 3, largest response reached (Emax), in percent of the reference or control that the assay uses: 106%
Estimate against measurement, compound 3: 9 percentage points above, within the range that was stated.
By their numbers in this assay, from the lowest: compound 3; then compounds 2 and 1 (each within the scatter of the next).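

Cyano in place of methylsulfonyl gives a number 14 percentage points lower from compound 2 to compound 3 (beyond the scatter) in this assay; this is the first step in the series to lie beyond the scatter, whereas the only earlier step, a change of configuration as drawn, stayed within it. The group on the aromatic carbon para to a large group therefore affects the maximal response in a way that the pair of mirror images could not show, and with the 4-cyanophenyl group compound 3 still gives 106% of the reference. No measurement at hand gives a cause for this step.

Open is whether the same exchange gives a step of similar size in the configuration drawn for compound 1, as cyano is shown here only in the configuration of compound 2. Also open, going by these compounds, is how the maximal response changes with other groups at this position, such as a carboxylic acid, an amine or trifluoromethyl, and whether any of them would take it above or below the values seen with methylsulfonyl and cyano.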